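The source may report more compounds than this note shows. Statements on the series, on what has been measured and on what is new or still open speak of the compounds shown alone.

Measured compounds in a functional assay on HeLa cells (Homo sapiens) for antiproliferative activity, with a stated time of 24 h; on this read-out higher numbers stand for weaker inhibition and lower numbers for stronger inhibition:
- compound 1 `NC(=O)c1c(NC(=O)c2ccccc2Cl)sc2c1CCN(Cc1ccc([N+](=O)[O-])cc1)C2`, which gives 46100 nM
- compound 2 `NC(=O)c1c(NC(=O)c2ccccc2Cl)sc2c1CCN(C(=S)Nc1ccccc1F)C2`, which gives 28700 nM

Compound 2 holds the lowest of the two numbers in this assay, with compound 1 nearest at a step of a 1.6-fold lower number from compound 1 to compound 2 (0.21 log units; within the scatter), so the two stand within the scatter of each other and no order between them can be read.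

Compound 3 `NC(=O)c1c(NC(=O)c2ccccc2Cl)sc2c1CCN(C(=S)Nc1ccccc1Br)C2` is the next point in the series. It differs from compound 2 by bromo in place of fluoro on an aromatic carbon, an exchange of one halogen for another on an aromatic carbon of a six-membered aromatic ring of carbon only, ortho to a large group.

For the measured compounds named here, none of the measured steps bears on this change: the one step measured, from compound 1 to compound 2, exchanges the whole group on the amine nitrogen in the ring and says nothing about a halogen swap within the 2-fluorophenyl group. In the absence of a comparable step, no movement beyond the scatter is expected in this assay; the step from compound 2 to compound 3 is estimated at a 1.1-fold lower number from compound 2 to compound 3 (0.06 log units; within the scatter). For compound 3 the expected value is 25000 nM, with a range from 9000 nM to 70000 nM.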

Compound 3, half-maximal inhibitory concentration: 24600 nM
Beside the measured number, compound 3's estimate is 1.0-fold (0.01 log units) above it, within the range that was stated.
By their numbers in this assay, from the lowest: compounds 3, 2 and 1 (each within the scatter of the next).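

In this assay, the exchange at the aromatic carbon ortho to a large group, 2-fluorophenyl to 2-bromophenyl, gives a 1.2-fold lower number from compound 2 to compound 3 (0.07 log units; within the scatter) and so stays within the scatter: at this position, the read-out does not tell these two halogens apart. For the compounds shown here, this is the first comparison made within the aryl group itself, as the earlier step exchanged the whole group on the amine nitrogen in the ring. The corresponding exchange of that whole group in the bromo compound gives a 1.9-fold lower number from compound 1 to compound 3 (0.27 log units; within the scatter), so all three compounds remain within the scatter of one another, and neither the halogen nor the group on that nitrogen yet separates any pair; no measurement at hand bears on the reason for this result.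

As far as these compounds go, whether a non-halogen group on this aromatic carbon, such as methoxy, an amine or a carboxylic acid, would move the number beyond the scatter remains open. Also open, from the compounds shown here alone, is whether any exchange elsewhere on the shared core, for instance at the primary amide, would separate compounds in this assay.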